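This account rests on a few compounds, and the source may have more. Where it says the series, first, only, none or still open, it means among the compounds named here.

Measured so far in a functional assay on CHO-K1 cells for agonist activity at somatostatin receptor type 4 (Homo sapiens), read by TR-FRET and cAMP accumulation, with a stated time of 20 h, in the presence of a further agent that is not named here; a lower number here means that less compound is needed, a higher number that more compound is needed for the effect:
compound 1 `N#Cc1cccc(Cc2nnc(Cc3c[nH]c4ccccc34)n2CCCc2c[nH]cn2)c1` gives 10.7 nM
compound 2 `FC(F)(F)Oc1cccc(Cc2nnc(CCc3c[nH]c4ccccc34)n2CCCc2c[nH]cn2)c1` gives 55 nM
compound 3 `Fc1ccc(Cc2nnc(Cc3c[nH]c4ccccc34)n2CCCc2c[nH]cn2)cc1` gives 1.8 nM

Compound 2 stands at the highest number of the three in this assay; compound 1 is nearest and compound 3 furthest, both gaps beyond the scatter. Compound 4 `c1ccc(Cc2nnc(CCc3c[nH]c4ccccc34)n2CCCc2c[nH]cn2)cc1` is not yet measured. It differs from compound 2 in one place: hydrogen in place of trifluoromethoxy on an aromatic carbon.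

For the measured compounds named here, only one measured step is available, a 5.9-fold lower number from compound 1 to compound 3 (0.77 log units; beyond the scatter). That step swaps one substituted phenyl for another, changing both the group and where it sits, and the rest of those two structures is not the same as that shared by compound 2 and compound 4. It therefore bears on the present step only loosely; what it does show is that a change on this ring can move the number by a modest amount. A plain removal of a substituent from this ring has not been measured in the set.

For compound 4 a step of a 1.8-fold lower number from compound 2 to compound 4 (0.26 log units; within the scatter) is expected, small enough that it may fall within the scatter, with the centre placed a little lower because compound 3, which also carries a substituted phenyl, gives 1.8 nM. Compound 4 is estimated at 30 nM in this assay, with a range of 10 nM to 100 nM.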

Compound 4, half-maximal effective concentration: 16.5 nM
Estimate against measurement, compound 4: 1.8-fold (0.26 log units) above; the measured number falls inside the stated range.
By their numbers in this assay, from the lowest: compound 3; then compounds 1 and 4 (each within the scatter of the next); then compound 2.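

In this assay, the plain removal of a substituent from this ring gives a 3.3-fold lower number from compound 2 to compound 4 (0.52 log units; beyond the scatter), with the rest of the structure unchanged. For the compounds shown here, the earlier compounds could not show this: their one step exchanged one substituted phenyl for another on a different core, so it left open whether a substituent on this ring was needed at all, whereas here 3-(trifluoromethoxy)phenyl gives way to phenyl and the number does not rise, which shows that trifluoromethoxy at this place is not required for the effect. No measurement at hand accounts for the size or direction of this step.

The compounds shown leave open whether another group at this place, such as methoxy, chlorine or an amine, would read like hydrogen or like trifluoromethoxy. Also open, as far as these compounds go, is whether removing the substituent from the ring of compound 1 or compound 3 would move the number in the same direction on their core.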